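Enone series: 2-chlorophenyl analogue of compound 2

A few compounds are considered here, and "the series" means these few. Any claim that something is new, unique, unknown or untested is made for them only; others in the source may bear on it.

Measured so far:
- compound 1 `COc1ccc(C(=O)/C(=C/c2ccccc2F)CCOC(C)=O)cc1` — > 100000 nM
- compound 2 `COc1ccc(C(=O)/C(=C/C2CCCCC2)CCOC(C)=O)cc1` — > 100000 nM

In a functional assay on NB-4 cells (Homo sapiens) for inhibition, read by XTT assay, with a stated time of 48 h (a higher number here means a weaker inhibitor, a lower number a stronger inhibitor), compound 1 reports only a limit, > 100000 nM, not a number. Compound 2 likewise gives only a limit in this assay, > 100000 nM. The step that the two limits leave unreadable from compound 1 to compound 2 cannot be read because both ends sit at the limit of > 100000 nM in this assay, at which 2 of the 2 values shown sit. Within the data shown here, compound 2 therefore stands at the limit with no number of its own, and the one further value shown is also a limit.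

Compound 3 `COc1ccc(C(=O)/C(=C/c2ccccc2Cl)CCOC(C)=O)cc1` differs from compound 2 in 2-chlorophenyl in place of cyclohexyl on a double-bonded chain carbon bound to a double-bonded chain carbon. Among the measured compounds shown here, the only measured step at the same place, a step that the two limits leave unreadable from compound 1 to compound 2, is unreadable, so neither direction nor size can be taken from it. No step beyond the scatter is expected, and compound 3 is expected to report a limit as well. Compound 3 is estimated at 100000 nM, within 30000 nM to 300000 nM. The expected step is a number no higher from compound 2 to compound 3 (the limit leaves the size open), within the scatter.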

Compound 3, half-maximal inhibitory concentration: 51600 nM
Compound 3: the middle estimate sits 1.9-fold (0.29 log units) above what was measured, within the range that was stated.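

In this assay compound 3 gives 51600 nM as the only number among the three compounds shown, so this position on the double-bonded chain carbon now has one measured end. The record holds an at least 1.9-fold lower number from compound 2 to compound 3 (0.28 log units; that floor lies within the scatter) and, for chloro in place of fluoro on an aromatic carbon, an at least 1.9-fold lower number from compound 1 to compound 3 (0.28 log units; that floor lies within the scatter) as floors only, so neither 2-chlorophenyl over cyclohexyl nor chloro over fluoro can be called a gain. The step from compound 1 to compound 2 remains unreadable, with both ends at a limit: the limit of > 100000 nM in this assay, at which 2 of the 3 values shown sit.

Going by these compounds, the true size of both new steps stays open, as the values of compound 1 and compound 2 are limits and not numbers. Also open, on these data alone, is how an amine or a carboxylic acid at this position would read.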